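Replacing the Aryl Group of Compound 3

The compounds below may be only part of what the source reports. "The series", "measured", "known", "first", "only" and "open" are said of these compounds alone.

In a functional assay on MCF7 cells (Homo sapiens) for antiproliferative activity, read by MTT assay, with a stated time of 72 h (on this read-out lower numbers stand for stronger inhibition and higher numbers for weaker inhibition), compound 1 (`COc1ccccc1-c1ccc2ncn(-c3cc(OC)c(OC)c(OC)c3)c2c1`) gives 1750 nM, compound 2 (`COc1cc(-n2cnc3ccc(-c4cccc(F)c4)cc32)cc(OC)c1OC`) gives 2350 nM and compound 3 (`COc1cc(-n2cnc3ccc(-c4cccc([N+](=O)[O-])c4)cc32)cc(OC)c1OC`) gives 4560 nM. Compound 3 therefore stands close to one neighbour and further from the other: the data show a 1.9-fold higher number from compound 2 to compound 3 (0.29 log units; within the scatter), and also a 2.6-fold higher number from compound 1 to compound 3 (0.42 log units; beyond the scatter).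

The next compound, compound 4 (`COc1cc(-n2cnc3ccc(-c4ccc(Cl)cc4Cl)cc32)cc(OC)c1OC`), carries 2,4-dichlorophenyl in place of 3-nitrophenyl on an aromatic carbon. All three measured steps change the group at this same place. Alongside those two, the data show a 1.3-fold higher number from compound 1 to compound 2 (0.13 log units; within the scatter). The largest of the three is only modest, so a large step is not expected here. However, no measured compound carries chlorine, so the 2,4-dichlorophenyl group remains untested in this assay.

A small move toward the values of the other two compounds is expected, with nothing beyond the scatter, and the estimate is a 1.6-fold lower number from compound 3 to compound 4 (0.21 log units; within the scatter). For compound 4 the estimated value is 2800 nM, within an expected range of 1100 nM to 6500 nM.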

Compound 4, half-maximal inhibitory concentration: 5420 nM
Compound 4: the middle estimate sits 1.9-fold (0.29 log units) below what was measured; the range from low to high includes it.
By their numbers in this assay, from the lowest: compounds 1, 2, 3 and 4 (each within the scatter of the next, the first and the last beyond it).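

In this assay, among these compounds, the first chlorine-bearing group at this position gives a result that cannot be separated from the nitro compound, with a 1.2-fold higher number from compound 3 to compound 4 (0.08 log units; within the scatter) for 2,4-dichlorophenyl in place of 3-nitrophenyl. Measured against the other two aryl groups, the same group gives a 2.3-fold higher number from compound 2 to compound 4 (0.36 log units; beyond the scatter) and a 3.1-fold higher number from compound 1 to compound 4 (0.49 log units; beyond the scatter), so two chlorines are accepted here and all steps at this place remain modest. No measurement available here explains these differences.

The compounds shown leave open which chlorine, if either, drives the steps from compound 2 and compound 1, since neither 2-chlorophenyl nor 4-chlorophenyl appears among them. They also leave open whether an amine or a carboxylic acid on this aryl ring would move the number further than any group seen so far.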